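Coumarin hydrazide to primary amine against monoamine oxidase A

The source may report more compounds than this note shows. Statements on the series, on what has been measured and on what is new or still open speak of the compounds shown alone.

Compound 1 `NNC(=O)Cc1cc(=O)oc2cc(OCc3cccc(Cl)c3)ccc12` is the stronger of two coumarin derivatives in an assay (strain Wistar) for inhibition of Amine oxidase [flavin-containing] A (Rattus norvegicus) (on this read-out higher numbers stand for weaker inhibition and lower numbers for stronger inhibition), where compound 1 gives 2500 nM. Compound 2 `CN(C)C(=O)Cc1cc(=O)oc2cc(OCc3ccccc3)ccc12` gives 23100 nM in this assay, a weaker result that is beyond the scatter. Compound 3 `NCc1cc(=O)oc2cc(OCc3cccc(Cl)c3)ccc12` has not been measured; it differs from compound 1 by amino in place of aminocarbamoyl on a saturated chain carbon bound to an aromatic carbon. Among the compounds with values here, no measured pair shows this change, so the step of a 2.4-fold higher number from compound 1 to compound 3 (0.38 log units; beyond the scatter) is only an expectation, and a modest loss is anticipated. Compound 3 is therefore estimated at 6000 nM in this assay, in a range from 1500 nM to 25000 nM.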

Compound 3, half-maximal inhibitory concentration: 2000 nM
Compound 3: the middle estimate sits 3.0-fold (0.48 log units) above what was measured; the range from low to high includes it.
By their numbers in this assay, from the lowest: compounds 3 and 1 (each within the scatter of the next); then compound 2.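

In this assay, amino in place of aminocarbamoyl on a saturated chain carbon bound to an aromatic carbon gives a 1.3-fold lower number from compound 1 to compound 3 (0.10 log units; within the scatter) and so leaves the read-out unchanged within the scatter. At this place, with the rest of the core of compound 1 held fixed, the full aminocarbamoyl group can thus give way to amino, which compound 2 could not show because it differs from compound 1 in more than one place. Nothing here accounts for this result. On these data alone, whether a carboxylic acid, a hydroxyl or a longer amine chain on this carbon would read the same stays open.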